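This account rests on a few compounds, and the source may have more. Where it says the series, first, only, none or still open, it means among the compounds named here.

Compound 1 (`O=C(O)c1cnc(-c2ccccc2)[nH]c1=O`) is the starting point, and in a functional assay on the whole organism (strain Sprague-Dawley) for inhibition, with Rattus norvegicus as the target, with a stated time of 10 min (a higher number here means that more compound is needed for the effect, a lower number that less compound is needed), compound 1 gives 50 mg/kg. Compound 2 (`O=C(O)c1cnc(-c2ccccc2O)[nH]c1=O`) carries a hydroxy in place of hydrogen on an aromatic carbon. In this assay compound 2 gives > 5 mg/kg, which is a limit of the assay and not a number. Compound 2 therefore has no exact place on the scale.

The next change leads to compound 3 (`CCOc1ccccc1-c1ncc(C(=O)O)c(=O)[nH]1`): ethyl in place of hydrogen on an oxygen on an aromatic ring. In words, this puts ethyl in place of hydrogen on an oxygen on an aromatic ring, turning hydroxy to ethoxy.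

For the measured compounds named here, only one measured step bears on this change, a step that the limit leaves unreadable from compound 1 to compound 2. That step gives neither a size nor a direction, so the data offer little guidance. The expectation is therefore loose, with a value not far from the limit of compound 2 and a modest lean toward less compound being needed. The expected step, which is only an estimate, is an at least 1.6-fold lower number from compound 2 to compound 3 (0.22 log units; that floor lies within the scatter). For compound 3 the expected value is 3 mg/kg, with an estimated range from 0.4 mg/kg to 30 mg/kg.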

Compound 3, dose for 50% inhibition: 0.5 mg/kg
Beside the measured number, compound 3's estimate is 6.0-fold (0.78 log units) above it; low and high end bracket the measured number.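

Compound 2 stands only at a limit of the assay, not at a number, so the step from compound 1 to compound 2 cannot be read: the limit of > 5 mg/kg in this assay, at which 1 of the 3 values shown sits.

Compound 3 supplies the first readable result for this position in this assay: the ethoxy group gives a 100-fold lower number from compound 1 to compound 3 (2.00 log units; beyond the scatter), so a substituent here can go with far less compound being needed for the effect. Ethyl in place of hydrogen on the oxygen gives an at least 10-fold lower number from compound 2 to compound 3 (1.00 log units; beyond the scatter), which shows that turning hydroxy to ethoxy matters in its own right, although this step is a floor and not an exact size.

As far as these compounds go, what remains open is whether ethoxy is special or whether other groups in the same place would do as well, such as methoxy, a longer chain like propoxy, or an amine. With only these three compounds, nothing shows whether the gain depends on the oxygen, on the ethyl chain, or on both.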